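Chain lengthening on the shared core: notes toward compound 4

This account rests on a few compounds, and the source may have more. Where it says the series, first, only, none or still open, it means among the compounds named here.

Measured so far:
compound 1 `Cc1ccc(NC(=O)N[C@H](C)c2ccccc2)cc1` — 64%
compound 2 `CCc1ccc(NC(=O)N[C@H](C)c2ccccc2)cc1` — 44%
compound 3 `CCCCc1ccc(NC(=O)N[C@H](C)c2ccccc2)cc1` — 28%

All three were run in an ADME assay on the whole organism with Oryza sativa as the target, tested at 10 uM; on this read-out lower numbers stand for a stronger effect and higher numbers for a weaker effect at the one concentration tested. They share one core and differ only in the length of a chain on it: compound 2 is set apart from compound 1 by methyl in place of hydrogen on a saturated chain carbon bound to an aromatic carbon, and compound 3 from compound 1 by propyl in place of hydrogen on a saturated chain carbon bound to an aromatic carbon. Each lengthening lowered the read-out, with a number 20 percentage points lower from compound 1 to compound 2 (beyond the scatter), then a number 16 percentage points lower from compound 2 to compound 3 (beyond the scatter), and over both steps of a number 36 percentage points lower from compound 1 to compound 3 (beyond the scatter). Compound 3 stands lowest of the three, its steps to both others beyond the scatter.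

Compound 4 `CCCCCc1ccc(NC(=O)N[C@H](C)c2ccccc2)cc1` is not yet measured. It differs from compound 3 by methyl in place of hydrogen on a saturated chain carbon, four bonds along the chain from an aromatic carbon. The same kind of change was made from compound 1 to compound 2, where it gave a modest step. The place is not the same: in the earlier change the entering methyl sits on a saturated chain carbon bound to an aromatic carbon, whereas here it sits on a saturated chain carbon, four bonds along the chain from an aromatic carbon. So it is the same kind of change, not the same change.

Across compounds 1, 2 and 3 the read-out has fallen with each added carbon, and no measured compound goes against this. On that basis a further fall is expected for compound 4, estimated as a number 10 percentage points lower from compound 3 to compound 4 (within the scatter), somewhat smaller than the earlier step because compound 3 already gives 28%. Compound 4 is expected to give about 18% in this assay, between 8% and 32%.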

Compound 4, a percentage reported as activity, at one concentration (the size of the read-out at that concentration, not a potency): 97%
Compound 4: middle estimate off by 79 percentage points, on the low side, outside the stated range (above it).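

In this assay, methyl in place of hydrogen on a saturated chain carbon does not carry over from one core to another as a predictable step, and the direction itself changes: the same change on two cores in this assay, a number 20 percentage points lower (beyond the scatter) from compound 1 to compound 2 and a number 69 percentage points higher (beyond the scatter) from compound 3 to compound 4, 89 percentage points apart, beyond the scatter of two such steps
The longer additions read the same way, with the lowering seen on the core of compound 1 standing against a rise on the core of compound 2: the same change on two cores in this assay, a number 36 percentage points lower (beyond the scatter) from compound 1 to compound 3 and a number 53 percentage points higher (beyond the scatter) from compound 2 to compound 4, 89 percentage points apart, beyond the scatter of two such steps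
Compound 4 goes against the fall across compounds 1, 2 and 3, with a number 69 percentage points higher from compound 3 to compound 4 (beyond the scatter), a number 53 percentage points higher from compound 2 to compound 4 (beyond the scatter) and a number 33 percentage points higher from compound 1 to compound 4 (beyond the scatter), so chain length alone gives no steady trend in this series, but the data do not show what produces the reversal, and the whole turn rests on this single compound.

Still open, going by these compounds, is whether a longer chain on the shared core keeps the read-out as high as in compound 4 or brings it back towards the level of compound 3, which would separate a lasting break from an isolated outlier. Also open, on these data alone, is how a chain carrying an amine or a carboxylic acid would read in this assay.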